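Swapping the Aryl Group on an Aromatic Nitrogen

A few compounds are considered here, and "the series" means these few. Any claim that something is new, unique, unknown or untested is made for them only; others in the source may bear on it.

Compound 1, `COc1cc2c(Oc3ccc(NC(=O)c4nn(-c5ccccc5C(F)(F)F)c(=O)cc4C)cc3F)ccnc2cc1OCCCN1CCCC1`: in a functional assay on HT-29 cells (Homo sapiens) for inhibition, read by MTT assay, with a stated time of 72 h (on this read-out lower numbers stand for stronger inhibition and higher numbers for weaker inhibition), compound 1 gives 140 nM.
Compound 2, `COc1cc2c(Oc3ccc(NC(=O)c4nn(-c5cccc(F)c5)c(=O)cc4C)cc3F)ccnc2cc1OCCCN1CCCC1`: in this assay compound 2 gives 250 nM.

Of the two numbers, compound 2 has the larger, though the step of a 1.8-fold higher number from compound 1 to compound 2 (0.25 log units; within the scatter) does not go beyond the scatter. Compound 3, `COc1ccc(-n2nc(C(=O)Nc3ccc(Oc4ccnc5cc(OCCCN6CCCC6)c(OC)cc45)c(F)c3)c(C)cc2=O)cc1`, differs from compound 2 by 4-methoxyphenyl in place of 3-fluorophenyl on an aromatic nitrogen. Among the measured compounds shown here, the only measured step that bears on this is a 1.8-fold higher number from compound 1 to compound 2 (0.25 log units; within the scatter), another swap of the aryl group on the same aromatic nitrogen, and it stayed within the scatter. Compound 3 is therefore expected to show no step beyond the scatter, no change at the digits printed from compound 2 to compound 3 (within the scatter). For compound 3 the estimate in this assay is 250 nM, within 100 nM to 700 nM.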

Compound 3, half-maximal inhibitory concentration: 3300 nM
The estimate for compound 3 lay 13-fold (1.12 log units) below the measured number; the whole stated range lies below it.
By their numbers in this assay, from the lowest: compounds 1 and 2 (each within the scatter of the next); then compound 3.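

At this aromatic nitrogen in this assay, the aryl group can matter a great deal: 4-methoxyphenyl gives a 13-fold higher number from compound 2 to compound 3 (1.12 log units; beyond the scatter) and also a 24-fold higher number from compound 1 to compound 3 (1.37 log units; beyond the scatter) when set against the other aryl group. Thus the earlier swap's stay within the scatter does not hold for every aryl group at this position. Nothing in the data given accounts for this large step.

Since the ring's substituent and its location change together here, the compounds shown cannot separate the two. They also leave open how a plain phenyl group, a pyridyl group or a phenyl ring carrying an amine would behave at this nitrogen.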